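The compounds below may be only part of what the source reports. "The series", "measured", "known", "first", "only" and "open" are said of these compounds alone.

Series notes on a shared core carrying a methylsulfonylbenzyl arm. Compound 1 `CS(=O)(=O)c1ccc(Cc2nnc3n2N=C(c2ccc(-c4ccccc4)cc2)CS3)cc1` gives 74.8% in a functional assay on RAW264.7 cells (Mus musculus) for cytotoxicity, read by MTT assay, with a stated time of 48 h, tested at 100 uM; a lower number here means a weaker effect, a higher number a stronger effect of the compound at the concentration tested. Compound 2 `CS(=O)(=O)c1ccc(Cc2nnc3n2N=C(c2cc(Cl)sc2Cl)CS3)cc1` gives 47.3% in this assay, the second highest of the three numbers; compound 1 stands higher by a margin beyond the scatter, and compound 3 `CS(=O)(=O)c1ccc(Cc2nnc3n2N=C(c2cc4ccccc4c(=O)o2)CS3)cc1` stands furthest away with 10.6%, lower by a margin beyond the scatter. Thus compound 2 sits between the two others and is separated from each of them by more than the usual scatter.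

The next compound, compound 4 `CS(=O)(=O)c1ccc(Cc2nnc3n2N=C(c2ccc(O)c(C(N)=O)c2)CS3)cc1`, is not yet measured in this assay. Relative to compound 2 the change is 3-carbamoyl-4-hydroxyphenyl in place of 2,5-dichlorothiophen-3-yl on a carbon with a double bond to nitrogen. Among the measured compounds shown here, no step between measured compounds is known for this pairing. The three measured numbers only show that the group on the carbon with a double bond to nitrogen moves the read-out widely. A decrease beyond the scatter is expected for a number 22.3 percentage points lower from compound 2 to compound 4 (beyond the scatter), in the direction of compound 3, whose number is 10.6%. Compound 4 is therefore estimated at 25%, with a range from 8% to 50%.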

Compound 4, a percentage reported as activity, at one concentration (the size of the read-out at that concentration, not a potency): 37.1%
Compound 4: middle estimate off by 12.1 percentage points, on the low side; the measured number falls inside the stated range.
By their numbers in this assay, from the lowest: compound 3; then compound 4; then compound 2; then compound 1.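

Among the compounds shown here, replacing 2,5-dichlorothiophen-3-yl with 3-carbamoyl-4-hydroxyphenyl on the carbon with a double bond to nitrogen gives the first single-change reading at this position in this assay: a number 10.2 percentage points lower from compound 2 to compound 4 (beyond the scatter) is a modest step, much smaller than the spread among the earlier compounds. A six-membered aromatic ring of carbon only, bearing both new substituents, therefore leaves compound 4 at 37.1% in the middle of the series, and not near compound 3 at 10.6% or compound 1 at 74.8% in the printed values. No supporting data on the compounds bear on the origin of this step.

The compounds shown do not separate the contribution of the hydroxy group from that of the carbamoyl group. From the compounds shown here alone, how a carboxylic acid or an amine in place of the carbamoyl group would read also remains open.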